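Swapping the unsaturated chain on a shared core

The compounds below may be only part of what the source reports. "The series", "measured", "known", "first", "only" and "open" are said of these compounds alone.

Compound 1 `CCCCC/C=C\C/C=C\CCCCCCCc1cc(=O)c2c(O)c(C)c(OCOC)c(C)c2o1`: 16100 nM
Compound 2 `CC/C=C\C/C=C\C/C=C\CCCCCCCc1cc(=O)c2c(O)c(C)c(OCOC)c(C)c2o1`: 16100 nM
Compound 3 `CCCC/C=C\CCCCCCCCCc1cc(=O)c2c(O)c(C)c(OCOC)c(C)c2o1`: not yet measured

In a functional assay on MDA-MB-231 cells (Homo sapiens) for antiproliferative activity, read by MTT assay (on this read-out lower numbers stand for stronger inhibition and higher numbers for weaker inhibition), compound 2 gives 16100 nM, level with compound 1 at 16100 nM. Compound 3 keeps the shared core and differs from compound 2 only in the chain: a group of 8 heavy atoms (8 carbon; no ring) in place of a group of 10 heavy atoms (10 carbon; no ring), on a saturated chain carbon, seven bonds along the chain from an aromatic carbon. Among the compounds with values here, one measured step bears on this change: no change at the digits printed from compound 1 to compound 2 (within the scatter). That step also lay in the chain, replacing butyl with but-1-en-1-yl, and it left the value unmoved. Within the data shown here, it is a smaller change than the one here, and no measured compound carries oct-3-en-1-yl, so it offers limited guidance. On that single step, no change beyond the scatter is expected in this assay, and neither direction is favoured. The expected size is a 1.0-fold lower number from compound 2 to compound 3 (0.00 log units; within the scatter). Compound 3 is estimated at 16000 nM, with an expected range of 7000 nM to 35000 nM.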

Compound 3, half-maximal inhibitory concentration: > 87000 nM
Compound 3: only a limit was reported; the forecaster's own chance of this, stated with the estimate: 10%; middle value at least 5.4-fold (0.73 log units) away from the limit.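

In this assay compound 3 gives no number, only a limit: the limit of > 87000 nM in this assay, at which 1 of the 3 values shown sits.

The chain at this position therefore does not tolerate every change, although the earlier swap of butyl for but-1-en-1-yl gave no change at the digits printed from compound 1 to compound 2 (within the scatter). Here, oct-3-en-1-yl in place of the group of 10 heavy atoms gives an at least 5.4-fold higher number from compound 2 to compound 3 (0.73 log units; beyond the scatter), and oct-3-en-1-yl in place of deca-1,4-dien-1-yl gives an at least 5.4-fold higher number from compound 1 to compound 3 (0.73 log units; beyond the scatter), so the weaker result appears against both earlier chains.

Because this change alters the chain's length and its number of double bonds together, the compounds shown cannot separate the two. Going by these compounds, it remains open whether a longer chain with one double bond, or a fully saturated octyl chain, would sit nearer compound 1 or compound 3.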